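A few compounds are considered here, and "the series" means these few. Any claim that something is new, unique, unknown or untested is made for them only; others in the source may bear on it.

Within the data shown here, only three compounds have been tested so far in an ADME assay on CHO cells (Cricetulus griseus) for inhibition, read by MTT assay; a lower number here means a stronger inhibitor, a higher number a weaker inhibitor. Compound 1 `CCN(CC)Cc1cc(F)cc(Nc2nc3ccccc3n2Cc2ccc(C(F)(F)F)cc2)c1O` reads > 50000 nM, which is a limit of the assay and not a number. Compound 3 `CCNCc1cc(Cl)cc(Nc2nc3cc(F)c(F)cc3n2Cc2ccc(C(F)(F)F)cc2)c1O` reads > 50000 nM, which is also a limit. The results so far are therefore marked by the limit of > 50000 nM in this assay, at which 2 of the 3 values shown sit. Among the measured compounds shown here, compound 2 `CC(C)(C)NCc1cc(C(C)(C)C)cc(Nc2nc3cc(F)c(F)cc3[nH]2)c1O` gives 34200 nM, the only true number available, so it offers the one firm reference point but cannot be ranked exactly against the other two.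

The next compound to be measured is compound 4 `CC(C)(C)NCc1cc(Cl)cc(Nc2nc3cc(F)c(F)cc3[nH]2)c1O`. The change from compound 2 is chloro in place of tert-butyl on an aromatic carbon. The new chloro group sits on the same aromatic carbon, para to a hydroxy group, and the ((tert-butyl)amino)methyl group stays in place.

For the measured compounds named here, no measured pair of compounds isolates this swap, so its size cannot be read from the data. The expectation rests on compound 2 at 34200 nM, and no change beyond the usual scatter is expected, with at most a slight drift towards weaker inhibition. The expected change is a 1.1-fold higher number from compound 2 to compound 4 (0.05 log units; within the scatter) in this estimate. For compound 4 the estimated value is 38000 nM, with an expected range from 17000 nM to 50000 nM.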

Compound 4, half-maximal inhibitory concentration: 39700 nM
For compound 4 the middle estimate is 1.0-fold (0.02 log units) below the measured one; low and high end bracket the measured number.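

Among these compounds, this is the first pair of compounds that isolates the group on the aromatic carbon para to a hydroxy group, and in this assay chloro in place of tert-butyl gives a 1.2-fold higher number from compound 2 to compound 4 (0.06 log units; within the scatter). A tert-butyl group of 4 heavy atoms and a chloro group of 1 heavy atom therefore cannot be told apart here, with the ((tert-butyl)amino)methyl group and the rest of the shared core unchanged, so this one exchange gives no sign that the group at this position governs the read-out. The pair also adds a second true number, yet the series still has little measured range in which a difference could show, and the readings that are limits remain unranked: the limit of > 50000 nM in this assay, at which 2 of the 4 values shown sit.

Compound 1 and compound 3 each differ from compound 4 in more than one place, so their steps cannot be read. Going by these compounds, it remains open whether an amine or a carboxylic acid on this same aromatic carbon would shift the number beyond the usual scatter, and whether chloro and tert-butyl would still read alike with a longer chain on the amine nitrogen.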